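A few compounds are considered here, and "the series" means these few. Any claim that something is new, unique, unknown or untested is made for them only; others in the source may bear on it.

Among the measured compounds shown here, compound 2, `C#CCNC1CCc2c(SCc3ccc(C)cc3)cccc21`, is the only member of this small set to give a number in an assay on isolated protein for inhibition of Amine oxidase [flavin-containing] B (Homo sapiens); a lower number here means a stronger inhibitor, a higher number a weaker inhibitor: in this assay compound 2 gives 1560 nM. Compound 1, `C#CCNC1CCc2c(SCc3cccc(C)c3)cccc21`, does not give a number: in this assay compound 1 gives > 100000 nM, which is a limit of the assay. For the measured compounds named here, the one measured step, a change of 4-methylphenyl in place of 3-methylphenyl on a saturated chain carbon bound to a sulfur, is an at least 64-fold lower number from compound 1 to compound 2 (1.80 log units; beyond the scatter), and that size rests on (the limit of > 100000 nM in this assay, at which 1 of the 2 values shown sits).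

Compound 3, `C#CCNC1CCc2c(SCc3cccc(Cl)c3)cccc21`, differs from compound 2 in one place: 3-chlorophenyl in place of 4-methylphenyl on a saturated chain carbon bound to a sulfur. Going by the values given here, the measured step bears on it only in that compound 3 returns to a 3-substituted phenyl, the arrangement that left compound 1 without a number; the chlorine itself has no measured counterpart here. Compound 3 is therefore expected to be a weaker inhibitor than compound 2, with an estimated step of a 16-fold higher number from compound 2 to compound 3 (1.20 log units; beyond the scatter) in this assay. The estimate for compound 3 in this assay is 25000 nM, in a range from 3000 nM to 150000 nM, with a real chance that only a limit is reported.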

Compound 3, half-maximal inhibitory concentration: 23300 nM
Estimate against measurement, compound 3: 1.1-fold (0.03 log units) above, and the stated range covers the measured number.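

With compound 3, a 3-substituted phenyl on a saturated chain carbon bound to a sulfur gives a number in this assay, so substitution at this place on the phenyl does not by itself lead to a limit of the assay. The substituent matters as well: chloro in place of methyl on an aromatic carbon gives an at least 4.2-fold lower number from compound 1 to compound 3 (0.63 log units; beyond the scatter), and the size of that step is only a bound, resting on the limit held by compound 1: the limit of > 100000 nM in this assay, at which 1 of the 3 values shown sits. Even so, the 3-chlorophenyl group does not match the 4-methylphenyl group in this assay, with a 15-fold higher number from compound 2 to compound 3 (1.17 log units; beyond the scatter), so the better number among these compounds still belongs to the 4-methylphenyl group.

The compounds shown leave open how much of that last step belongs to where the substituent sits and how much to chloro against methyl, a question that 4-chlorophenyl on the same carbon would address. Also open, going by these compounds, is how an unsubstituted phenyl, a 4-methoxyphenyl or a longer chain between the sulfur and the phenyl would read in this assay.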